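A Fluoro-for-Nitro Swap on a Shared Core

This account rests on a few compounds, and the source may have more. Where it says the series, first, only, none or still open, it means among the compounds named here.

Measured compounds in a functional assay on B16-F10 cells (Mus musculus) for cytotoxicity; a higher number here means a weaker inhibitor, a lower number a stronger inhibitor:
compound 1, `O=c1oc2ccccc2c2nc3c(ccc4cc[nH]c43)c(-c3cccc4ccccc34)c12`: 70700 nM
compound 2, `O=c1cc(O)c2cc(F)ccc2o1`: 70700 nM
compound 3, `O=c1oc2ccccc2c2nc3c(ccc4cc[nH]c43)c(-c3ccc([N+](=O)[O-])cc3)c12`: 70700 nM

Compound 3 sits level with both of its neighbours in this assay. Among the measured compounds shown here, its nearest comparison is compound 1, and the single measured step, no change at the digits printed from compound 1 to compound 3 (within the scatter), shows no change within the scatter when 4-nitrophenyl replaces naphthalen-1-yl on an aromatic carbon. Compound 2, a much smaller molecule, reaches the same value, so the three measured compounds give no spread at all to build on.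

Compound 4, `O=c1oc2ccccc2c2nc3c(ccc4cc[nH]c43)c(-c3ccc(F)cc3)c12`, differs from compound 3 by fluoro in place of nitro on an aromatic carbon, sitting on the six-membered aromatic ring of carbon only, para to a large group. For the measured compounds named here, the one step that bears on this position, from naphthalen-1-yl to 4-nitrophenyl, was flat, and no step from nitro to fluoro has been measured here. The expectation for compound 4 in this assay is therefore a step of no change at the digits printed from compound 3 to compound 4 (within the scatter), that is, no change beyond the scatter. Compound 4 is estimated at 70700 nM, with a range from 30000 nM to 150000 nM.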

Compound 4, half-maximal inhibitory concentration: 70700 nM
Beside the measured number, compound 4's estimate shows no gap at the digits printed, and the stated range covers the measured number.
By their numbers in this assay, from the lowest: compounds 1, 2, 3 and 4 (each within the scatter of the next).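

In this assay, among the compounds shown here, the first measured change of the group on this aromatic carbon with the phenyl ring kept in place gives no change at the digits printed from compound 3 to compound 4 (within the scatter), even though nitro, with its 3 heavy atoms and 2 hydrogen-bond acceptors, gives way to fluoro, with 1 heavy atom and no acceptors. The wider replacement of naphthalen-1-yl by 4-fluorophenyl gives no change at the digits printed from compound 1 to compound 4 (within the scatter), so naphthalen-1-yl, 4-nitrophenyl and 4-fluorophenyl now all read alike on the shared core. No measurement shown here offers an explanation for this flat result.

The compounds shown leave open whether an amine or a carboxylic acid on the same aromatic carbon would move the value at all. With no spread among them, they also do not show which part of the shared core, if any, governs the reading.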